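From 4-methoxyphenyl to 3-methylphenyl: a small expected step

A few compounds are considered here, and "the series" means these few. Any claim that something is new, unique, unknown or untested is made for them only; others in the source may bear on it.

Measured so far in a functional assay on A549 cells (Homo sapiens) for inhibition, read by MTT assay, with a stated time of 24 h (on this read-out lower numbers stand for stronger inhibition and higher numbers for weaker inhibition), for three compounds:
compound 1 `CC1(C)[C@H]2CC[C@]1(C)N(Cc1cn(-c3ccccc3Br)nn1)C(=O)C2` at 130 nM
compound 2 `CC1(C)[C@H]2CC[C@]1(C)N(Cc1cn(-c3cccc(Br)c3)nn1)C(=O)C2` at 90 nM
compound 3 `COc1ccc(-n2cc(CN3C(=O)C[C@@H]4CC[C@@]3(C)C4(C)C)nn2)cc1` at 50 nM

Compound 3 at 50 nM sits at the low end of these numbers, together with compound 2. Compound 4 `Cc1cccc(-n2cc(CN3C(=O)C[C@@H]4CC[C@@]3(C)C4(C)C)nn2)c1` has not been measured yet. It differs from compound 3 by 3-methylphenyl in place of 4-methoxyphenyl on an aromatic nitrogen with 3-methylphenyl in place of 4-methoxyphenyl on an aromatic nitrogen.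

The three measured compounds differ from one another at this same place, so their steps are the best guide. Two of those steps are small, a 1.4-fold lower number from compound 1 to compound 2 (0.16 log units; within the scatter) and a 1.8-fold lower number from compound 2 to compound 3 (0.26 log units; within the scatter) as well. The largest is a 2.6-fold lower number from compound 1 to compound 3 (0.41 log units; beyond the scatter) and even that one is modest. The closest comparison by name is compound 2 at 90 nM with its 3-bromophenyl group. A small move towards a higher number therefore seems likely, though three compounds are a thin basis.

In this assay the expected move is a 1.6-fold higher number from compound 3 to compound 4 (0.20 log units; within the scatter) and it would probably stay inside the usual scatter. For compound 4 the estimated value is 80 nM with an expected range from 35 nM to 180 nM for now.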

Compound 4, half-maximal inhibitory concentration: 50 nM
Compound 4: middle estimate off by 1.6-fold (0.20 log units), on the high side; the range from low to high includes it.
By their numbers in this assay, from the lowest: compounds 3, 4, 2 and 1 (each within the scatter of the next, the first and the last beyond it).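

In this assay the exchange of 4-methoxyphenyl for 3-methylphenyl gives no change at the digits printed from compound 3 to compound 4 (within the scatter) even though the oxygen and its hydrogen-bond acceptor leave, and methyl in place of bromo gives a 1.8-fold lower number from compound 2 to compound 4 (0.26 log units; within the scatter) so neither exchange on this aromatic nitrogen can be told apart from no effect. Against the 2-bromophenyl group there is a 2.6-fold lower number from compound 1 to compound 4 (0.41 log units; beyond the scatter) but this step is modest, and compound 1 also remains within the scatter of compound 2, so the position shows a shallow spread rather than a sharp demand for one group. Nothing available explains why these different rings give such close numbers.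

Because compound 3 and compound 4 differ in both the group on the ring and its place, the pair cannot separate those two changes, and 4-methylphenyl and 3-methoxyphenyl would be the direct tests. As far as these compounds go, it also remains open whether this tolerance would hold for a carboxylic acid or an amine on the phenyl ring, or for a cyclohexyl group in place of the phenyl ring.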